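Amide series: chloro to fluoro on the aromatic carbon

The source may report more compounds than this note shows. Statements on the series, on what has been measured and on what is new or still open speak of the compounds shown alone.

Measured so far:
- compound 1, `O=C(Nc1ccc2[nH]ncc2c1)c1c(F)cccc1Cl`: > 10000 nM, a limit of the assay
- compound 2, `O=C(Nc1ccc(F)c(Cl)c1)c1ccc2cn[nH]c2c1`: > 10000 nM, a limit of the assay

In an assay on cells for inhibition of Amine oxidase [flavin-containing] A (Rattus norvegicus) (a lower number here means a stronger inhibitor, a higher number a weaker inhibitor), compound 1 gives > 10000 nM, which is a limit and not a number. In this assay compound 2 gives > 10000 nM, again a limit. Both values sit at the limit of > 10000 nM in this assay, at which 2 of the 2 values shown sit, so compound 2 stands at the limit of this assay, with nothing known of how far beyond it the true value lies. Among the compounds with values here, no pair of measured compounds differs in one place, so no measured step is available.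

Compound 3, `O=C(Nc1ccc(F)c(F)c1)c1ccc2cn[nH]c2c1`, differs from compound 2 by fluoro in place of chloro on an aromatic carbon. With compound 2 only at a limit, the step from compound 2 to compound 3 is expected to be a step that the limit leaves unreadable from compound 2 to compound 3, that is, none beyond the scatter in this assay. Compound 3 is therefore estimated at 20000 nM, within a range from 5000 nM to 100000 nM, most likely reported as a limit again.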

Compound 3, half-maximal inhibitory concentration: > 10000 nM
Compound 3: a limit, no number (the forecaster's own chance of this, stated with the estimate: 85%); the middle value is on the limit's open side.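

Compound 2 and compound 3 both give a limit and not a number in this assay, so fluoro in place of chloro yields no readable step: the limit of > 10000 nM in this assay, at which 3 of the 3 values shown sit.

The compounds shown leave open how far beyond that limit any true value lies, and which structural change, if any, would bring a value within the range of this assay.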